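Five-membered ring swap on the salicylic acid series

The source may report more compounds than this note shows. Statements on the series, on what has been measured and on what is new or still open speak of the compounds shown alone.

Among the compounds with values here, compound 2 `O=C(O)c1cc(-c2cccs2)ccc1O` gives 60 mg/kg in a functional assay on the whole organism for inhibition, with Rattus norvegicus as the target, read by paw edema (a higher number here means that more compound is needed for the effect, a lower number that less compound is needed), the only plain number so far. Compound 1 `O=C(O)c1cc(-c2cncs2)ccc1O` gives in this assay only a limit, > 200 mg/kg. Within the data shown here, the single measured step runs an at least 3.3-fold lower number from compound 1 to compound 2 (0.52 log units; beyond the scatter), and its lower bound rests on (the limit of > 200 mg/kg in this assay, at which 1 of the 2 values shown sits). Compound 3 `O=C(O)c1cc(-n2ccnc2)ccc1O` differs from compound 2 by 1H-imidazol-1-yl in place of thiophen-2-yl on an aromatic carbon. The entering ring stands closer to the ring of compound 1 than to thiophen-2-yl in hetero atom and acceptor content, so the measured step is expected to run back in the opposite direction, toward a higher number in this assay. The change from compound 2 is estimated as a 2.5-fold higher number from compound 2 to compound 3 (0.40 log units; beyond the scatter). For compound 3 in this assay the estimate is 150 mg/kg, between 60 mg/kg and 400 mg/kg, with a real chance that only a limit is reported.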

Compound 3, dose for half-maximal effect: 75 mg/kg
The estimate for compound 3 lay 2.0-fold (0.30 log units) above the measured number; low and high end bracket the measured number.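

Working notes: at this position, meta to a carboxy group and para to a hydroxy group, replacing thiophen-2-yl with 1H-imidazol-1-yl in this assay gives a 1.3-fold higher number from compound 2 to compound 3 (0.10 log units; within the scatter), so ring sulfur is not needed to hold the number reached by compound 2. Ring nitrogen alone also does not account for the poor result of compound 1, since 1H-imidazol-1-yl carries ring nitrogen and the swap from 1,3-thiazol-5-yl gives an at least 2.6-fold lower number from compound 1 to compound 3 (0.42 log units; beyond the scatter). The size of that step stays open-ended, as it is set by a limit: the limit of > 200 mg/kg in this assay, at which 1 of the 3 values shown sits.

Still open, on these data alone, is whether attachment through ring nitrogen rather than ring carbon matters, as 1H-imidazol-1-yl and 1,3-thiazol-5-yl differ in more than that. Also open, as far as these compounds go, is how a phenyl ring, or an amine on the five-membered ring, would read at this position.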